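This account rests on a few compounds, and the source may have more. Where it says the series, first, only, none or still open, it means among the compounds named here.

Compound 1 `CC(=O)Nc1ccc(S(=O)(=O)NNc2ccc(F)cc2)cc1` gives 609 nM in an assay on HeLa cells for inhibition of Indoleamine 2,3-dioxygenase 1 (Homo sapiens), read by spectrophotometry, with a stated time of 24 h; a lower number here means that less compound is needed, a higher number that more compound is needed for the effect.
Compound 2 `CC(=O)Nc1ccc(S(=O)(=O)NNc2ccc(Cl)c(F)c2)cc1` gives 84 nM in this assay.
Compound 3 `O=S(=O)(NNc1ccc(Br)cc1)c1ccc(Br)cc1` gives 374 nM in this assay.

Among these three numbers, compound 3 stands second highest. Its nearest neighbour is compound 1, whose number is higher but only by a margin that lies within the scatter of repeated measurements, so the two cannot be told apart. Its furthest neighbour is compound 2, which gives a clearly lower number, a gap that lies beyond the scatter.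

Compound 4 `O=C(O)COc1ccc(S(=O)(=O)NNc2ccc(Br)cc2)cc1` has not yet been measured. It differs from compound 3 in one place: carboxymethoxy in place of bromo on an aromatic carbon. Among the compounds with values here, no pair of measured compounds shows this change on its own, so there is no measured step to lean on; the only guide is that a bulkier, more heavily heteroatom-laden group replaces a single halogen at a place para to a large group.

Without a measured precedent, the step is expected to be modest and to go toward a somewhat higher number in this assay, as a 2.1-fold higher number from compound 3 to compound 4 (0.33 log units; beyond the scatter). Compound 4 is therefore estimated at 800 nM, with a plausible range from 250 nM to 2500 nM.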

Compound 4, half-maximal effective concentration: 152 nM
Compound 4: middle estimate off by 5.3-fold (0.72 log units), on the high side; measured number below the stated range.
By their numbers in this assay, from the lowest: compounds 2 and 4 (each within the scatter of the next); then compounds 3 and 1 (each within the scatter of the next).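

Within the data shown here, putting carboxymethoxy in place of bromo on this aromatic carbon, para to a large group, gives a 2.5-fold lower number from compound 3 to compound 4 (0.39 log units; beyond the scatter) in this assay and is the first single change that can be read directly. It shows that a single halogen is not needed at this place, at least in this pair: the larger carboxymethoxy group, which brings a hydrogen-bond donor and hydrogen-bond acceptors that bromo lacks, still lowers the number rather than raising it. Nothing measured here explains why the number falls.

The compounds shown leave open which part of carboxymethoxy matters, and a plain methoxy, a methyl ester or a longer chain ending in a carboxylic acid at the same place would help separate the ether oxygen from the acid end. Also open, from the compounds shown here alone, is whether this one step carries over when the bromo at the other end of the molecule is replaced, for example by the chloro and fluoro substituents of compound 2.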